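From 4-fluorobenzyl to 2-(diethylamino)ethyl: a number still awaited

The compounds below may be only part of what the source reports. "The series", "measured", "known", "first", "only" and "open" are said of these compounds alone.

Compound 1 `COc1ccc(CNC(=O)c2c([N+](=O)[O-])noc2-c2ccc([N+](=O)[O-])cc2)cc1` gives 69600 nM as its value
Compound 2 `O=C(NCc1cccc(Cl)c1Cl)c1c([N+](=O)[O-])noc1-c1ccc(Cl)cc1` gives 73700 nM as its value
Compound 3 `COC(=O)c1c(NCc2ccc(F)cc2)noc1-c1ccc([N+](=O)[O-])cc1` gives "not determined" (no result reported) as its entry

All three compounds were examined in an ADME assay on J774.A1 cells (Mus musculus) for cytotoxicity, read by MTT assay, with a stated time of 48 h (a lower number here means that less compound is tolerated, a higher number that more compound is tolerated), on the same terms. Compound 1 and compound 2 lie within the usual scatter of each other. Compound 3 has no place on this scale, since its entry reads "not determined" (no result reported) and no number stands behind it.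

Compound 4 `CCN(CC)CCNc1noc(-c2ccc([N+](=O)[O-])cc2)c1C(=O)OC` has yet to be measured. Its structure departs from the previous one in a single place, as follows: (diethylamino)methyl in place of 4-fluorophenyl on a saturated chain carbon bound to a nitrogen on an aromatic ring (in words, (diethylamino)methyl in place of 4-fluorophenyl on a saturated chain carbon bound to a nitrogen on an aromatic ring).

Within the data shown here, with no number for compound 3, no step can be sized directly. Among the measured compounds shown here, the only anchors are compound 1 at 69600 nM and compound 2 at 73700 nM in this assay, so a modest move towards lower numbers is expected, with little certainty. Compound 4 is estimated at 45000 nM in this assay, with an expected range from 12000 nM to 120000 nM around that estimate.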

Compound 4, half-maximal cytotoxic concentration: 69300 nM
Compound 4: middle estimate off by 1.5-fold (0.19 log units), on the low side; the range from low to high includes it.
By their numbers in this assay, from the lowest: compounds 4, 1 and 2 (each within the scatter of the next).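

Among these compounds, compound 3 has no number in this assay, so no step to compound 4 at 69300 nM can be read. Nothing shown offers an explanation for this value. The compounds shown leave open what 2-(diethylamino)ethyl in place of 4-fluorobenzyl does to this read-out.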